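The compounds below may be only part of what the source reports. "The series", "measured", "known", "first", "only" and "open" are said of these compounds alone.

Of the compounds shown here, three carrying the benzoyl group have been tested in a functional assay on HepG2 cells (Homo sapiens) for antiproliferative activity, read by MTT assay, with a stated time of 48 h; on this read-out higher numbers stand for weaker inhibition and lower numbers for stronger inhibition: compound 1 (`O=C1/C(=C/c2ccc(F)cc2)CN(C(=S)NC(=O)c2ccccc2)C/C1=C\c1ccc(F)cc1`), compound 2 (`Cc1ccccc1/C=C1\CN(C(=S)NC(=O)c2ccccc2)C/C(=C\c2ccccc2C)C1=O`) and compound 3 (`Cc1ccc(/C=C2\CN(C(=S)NC(=O)c3ccccc3)C/C(=C\c3ccc(C)cc3)C2=O)cc1`). Compound 1 gives < 10000 nM as a limit and not a number. Compound 2 gives < 10000 nM as a limit as well. Compound 3, where this account starts, gives < 10000 nM as a limit too. For the measured compounds named here, the set therefore holds one shared position, (the limit of < 10000 nM in this assay, at which 3 of the 3 values shown sit), with no measured step between any two of its members, and compound 3 cannot be ranked against the other two.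

Compound 4 (`CCCCNC(=S)N1C/C(=C\c2ccc(C)cc2)C(=O)/C(=C/c2ccc(C)cc2)C1`) keeps the core of compound 3 and has butyl in place of benzoyl on an amide-type nitrogen, whose other neighbour is the thiocarbonyl carbon: butyl in place of benzoyl on an amide-type nitrogen. Going by the values given here, with no measured step to lean on, a modest move towards stronger inhibition in this assay is expected, though the direction is uncertain. That expectation has only compound 3 at < 10000 nM as its anchor, and this is a limit. The estimated step is a step that the limit leaves unreadable from compound 3 to compound 4 and remains an expectation. The estimate for compound 4 is 4000 nM within an expected range of 800 nM to 15000 nM.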

Compound 4, half-maximal inhibitory concentration: < 10000 nM
Compound 4: no number, only a limit; the forecaster's own chance of this, stated with the estimate: 50%; the middle value is on the limit's open side.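

No step can be read from compound 3 to compound 4, because both give a limit and not a number in this assay: the limit of < 10000 nM in this assay, at which 4 of the 4 values shown sit. The compounds shown leave open how they rank against one another, and whether butyl in place of benzoyl on an amide-type nitrogen strengthens inhibition, weakens it or leaves it unchanged.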